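Phenyl on the Core: From Compound 2 to Compound 4

The source may report more compounds than this note shows. Statements on the series, on what has been measured and on what is new or still open speak of the compounds shown alone.

Measured compounds:
compound 1 `O=C(Nc1nccn2cc(-c3ccccc3)nc12)c1ccccc1`, 52 nM
compound 2 `COc1ccc(-c2cn3ccnc(NC(=O)c4ccccc4)c3n2)cc1`, 121 nM
compound 3 `O=C(Nc1nc(-c2ccccc2)cn2cc(-c3ccccc3)nc12)c1ccc(Cl)cc1`, 156 nM

Three compounds share a core and were tested in an assay on cells for displacement of a labelled ligand from transmembrane domain-containing protein TMIGD3 (Homo sapiens), read by scintillation counting, with a stated time of 120 min; a higher number here means a weaker inhibitor, a lower number a stronger inhibitor. Compound 1 gives 52 nM. Compound 2 stands second highest of the three numbers: its nearest neighbour is compound 3, whose number is higher but within the scatter, and its furthest is compound 1, a lower number beyond the scatter. Within the data shown here, the only single-point step measured is a 2.3-fold higher number from compound 1 to compound 2 (0.37 log units; beyond the scatter), a modest weakening on adding a methoxy group.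

Compound 4 `COc1ccc(-c2cn3cc(-c4ccccc4)nc(NC(=O)c4ccccc4)c3n2)cc1` is not yet measured. It differs from compound 2 in one place: phenyl in place of hydrogen on an aromatic carbon. Among the measured compounds shown here, no measured step isolates this change. Compound 3 also carries a phenyl on the core, together with a chlorine on the benzamide, and its number is higher than that of compound 1 which lacks both, so the two changes together weaken binding in this assay beyond the scatter; how much of that belongs to the phenyl cannot be separated. A small to modest rise is therefore expected for compound 4, as a 1.5-fold higher number from compound 2 to compound 4 (0.17 log units; within the scatter), and compound 4 is estimated at 180 nM, in a range from 70 nM to 450 nM.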

Compound 4, inhibition constant: 312 nM
For compound 4 the middle estimate is 1.7-fold (0.24 log units) below the measured one; low and high end bracket the measured number.
By their numbers in this assay, from the lowest: compound 1; then compounds 2, 3 and 4 (each within the scatter of the next, the first and the last beyond it).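

In this assay the phenyl in place of hydrogen on an aromatic carbon of the six-membered aromatic ring with 2 nitrogen, meta to a benzamido group, gives a 2.6-fold higher number from compound 2 to compound 4 (0.41 log units; beyond the scatter) and so lies beyond the scatter. This is the first step shown that isolates the phenyl on this ring, whereas on compound 3 the same group comes together with a chlorine on the benzamide. The change weakens binding without losing it, since compound 4 gives 312 nM as a plain number.

Nothing among the data shown accounts for the rise. On these data alone, whether a methyl group or a morpholine in this place would move the number in the same way remains open, as does the effect of an amine or a carboxylic acid on the added phenyl. As far as these compounds go, it is also open whether the phenyl would give a step of similar size on compound 1, which lacks the methoxy group of compound 2.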